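Dimethylamino side chains on a dichlorophenyl pyrazine core

The source may hold more compounds than are shown below. What is called first, only, known or untested is meant among the compounds shown, and "the series" means these compounds.

In an assay on IMR-32 cells for displacement of a labelled ligand from corticotropin-releasing factor receptor 1 (Homo sapiens), read by scintillation counting, with a stated time of 2 h (a higher number here means a weaker inhibitor, a lower number a stronger inhibitor), compound 3 `CCCN(CCN(C)C)c1nc(CC)c(-c2ccc(Cl)cc2Cl)nc1CC` gives 1540 nM, the highest number of the three measured, with compound 1 `CCCN(CC1CC1)c1nc(CC)c(-c2ccc(Cl)cc2Cl)nc1CC` at 19.2 nM and compound 2 `CCc1nc(-c2ccc(Cl)cc2Cl)c(CC)nc1CC(CC)CC` at 68 nM. The two steps into compound 3 were both large: an 80-fold higher number from compound 1 to compound 3 (1.90 log units; beyond the scatter) and a 23-fold higher number from compound 2 to compound 3 (1.36 log units; beyond the scatter). Compound 4 `CCc1nc(-c2ccc(Cl)cc2Cl)c(CC)nc1NC(C)CN(C)C` differs from compound 3 by (1-((dimethylamino)methyl)ethyl)amino in place of (2-(dimethylamino)ethyl)(propyl)amino on an aromatic carbon. The dimethylamino-bearing chain, which accompanied the large loss in an 80-fold higher number from compound 1 to compound 3 (1.90 log units; beyond the scatter), is retained, so no recovery beyond the scatter is expected in this assay for compound 4, and the step for compound 4 is expected to be a 1.0-fold lower number from compound 3 to compound 4 (0.01 log units; within the scatter). Compound 4 is therefore expected to give 1500 nM, within 400 nM to 6000 nM.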

Compound 4, inhibition constant: 489 nM
Compound 4: middle estimate off by 3.1-fold (0.49 log units), on the high side, and the stated range covers the measured number.
By their numbers in this assay, from the lowest: compound 1; then compound 2; then compound 4; then compound 3.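

In this assay, keeping a dimethylamino group on the chain at this aromatic carbon does not fix the number: (1-((dimethylamino)methyl)ethyl)amino in place of (2-(dimethylamino)ethyl)(propyl)amino gives a 3.1-fold lower number from compound 3 to compound 4 (0.50 log units; beyond the scatter), so the form of the chain also counts. The recovery is only partial, with a 7.2-fold higher number from compound 2 to compound 4 (0.86 log units; beyond the scatter) and a 25-fold higher number from compound 1 to compound 4 (1.41 log units; beyond the scatter). No evidence here accounts for these steps.

On these data alone, whether the step follows the amine hydrogen of compound 4, its branched chain or the missing propyl group stays open. The compounds shown also leave open how a morpholine at the chain end would compare.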